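Replacing 4-chlorophenyl with hydroxymethyl at the amide carbonyl

The compounds below may be only part of what the source reports. "The series", "measured", "known", "first", "only" and "open" are said of these compounds alone.

In an assay on cells for inhibition of Amine oxidase [flavin-containing] B (Homo sapiens), read by fluorescence and Amplex Red, with stated times of 30 min and 15 min (on this read-out lower numbers stand for stronger inhibition and higher numbers for weaker inhibition), compound 3, `C#CCNC1CCc2c(OCCc3cc(NC(=O)c4ccc(Cl)cc4)ccc3Cl)cccc21`, gives only a limit, > 20000 nM. Compound 1, `C#CCNC1CCc2c(OCCc3cc(NC(=O)c4ccccc4)ccc3Cl)cccc21`, likewise stops at a limit, > 20000 nM. Compound 2, `C#CCNC1CCc2c(OCCc3cc(NC(=O)c4cccc(F)c4)ccc3Cl)cccc21`, also stops at a limit, > 20000 nM. Because all three sit at the limit of > 20000 nM in this assay, at which 3 of the 3 values shown sit, the steps a step that the two limits leave unreadable from compound 1 to compound 2, a step that the two limits leave unreadable from compound 1 to compound 3 and a step that the two limits leave unreadable from compound 2 to compound 3 cannot be sized. Compound 4, `C#CCNC1CCc2c(OCCc3cc(NC(=O)CO)ccc3Cl)cccc21`, differs from compound 3 by hydroxymethyl in place of 4-chlorophenyl on a carbonyl carbon. Among the compounds with values here, no measured step touches this change, and none has a readable size, so the data give no direction for compound 4 in this assay. Compound 4 is therefore expected to stay near the shared limit, a step that the limit leaves unreadable from compound 3 to compound 4, with an estimate of 25000 nM, between 6000 nM and 100000 nM.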

Compound 4, half-maximal inhibitory concentration: 270 nM
The estimate for compound 4 lay 93-fold (1.97 log units) above the measured number, outside the stated range (below it).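

In this assay, within the data shown here, the group on the amide carbonyl proves able to change the read-out, which the earlier compounds could not show: hydroxymethyl gives an at least 74-fold lower number from compound 3 to compound 4 (1.86 log units; beyond the scatter). The same change gives an at least 74-fold lower number from compound 2 to compound 4 (1.86 log units; beyond the scatter) and an at least 74-fold lower number from compound 1 to compound 4 (1.86 log units; beyond the scatter). The steps among the three compounds with aromatic groups remain unreadable because they share one limit: the limit of > 20000 nM in this assay, at which 3 of the 4 values shown sit.

As far as these compounds go, whether the gain comes from the hydroxyl or from the loss of the aromatic ring stays open. Methyl, a longer chain such as hydroxyethyl, or an amine at this carbonyl carbon would help separate the two.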